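Cyano in place of difluoromethoxy: expected effect on clearance

The compounds below may be only part of what the source reports. "The series", "measured", "known", "first", "only" and "open" are said of these compounds alone.

Measured compounds:
compound 1 `FC(F)Oc1ccccc1C1Cc2nccn2C1` — 22 mL.min-1.g-1
compound 2 `COc1ccccc1C1CCc2nc[nH]c2C1` — "not determined" (no result reported)

Among the compounds with values here, compound 1 is the only compound with a number in an in vitro ADME assay on microsomes from liver (Homo sapiens) for metabolic stability; a lower number here means slower removal, a higher number faster removal of the compound. In this assay compound 1 gives 22 mL.min-1.g-1, and compound 2 has no result in this assay, so compound 1 stands alone and cannot be ranked against anything measured. The unmeasured compound 3 `N#Cc1ccccc1C1Cc2nccn2C1` differs from compound 1 in a single place: cyano in place of difluoromethoxy on an aromatic carbon. Within the data shown here, no step between two measured compounds exists here, so the size of the change in this assay can only be guessed. Compound 3 is expected to be cleared somewhat more slowly than compound 1, with a step of a 2.0-fold lower number from compound 1 to compound 3 (0.30 log units; within the scatter) of modest size that may reach just beyond the scatter. For compound 3 the estimate in this assay is 11 mL.min-1.g-1, with a range from 4 mL.min-1.g-1 to 26 mL.min-1.g-1.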

Compound 3, intrinsic clearance in microsomes: < 7 mL.min-1.g-1
Compound 3 was reported as a limit; the forecaster's own chance of this, stated with the estimate: 5%; middle value at least 1.5-fold (0.19 log units) away from the limit.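

In this assay, within the data shown here, cyano in place of difluoromethoxy on an aromatic carbon gives an at least 3.1-fold lower number from compound 1 to compound 3 (0.49 log units; beyond the scatter) and so provides the first readable step at this position. The reading for compound 3 is a limit and not a number, which leaves the step with a bound on one side only: the limit of < 7 mL.min-1.g-1 in this assay, at which 1 of the 3 values shown sits. Between these two compounds, the number in this assay changes with the group at this position, and difluoromethoxy is not needed there for the lower reading.

Only this one replacement can be read, so the compounds shown do not tell whether the step reflects cyano itself or the departure of difluoromethoxy. From the compounds shown here alone, what a trifluoromethyl group, a chlorine atom or a carboxamide would do at this position stays open, as does whether the same step would hold on any other core.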